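Replacing one group in a cytotoxic long-chain compound

The source may hold more compounds than are shown below. What is called first, only, known or untested is meant among the compounds shown, and "the series" means these compounds.

Compound 1 `C#C/C=C\CCCCCCCCCCCCCC/C=C/CCCC/C=C/CCCCC#C[C@@H](O)C#CCCCCCC/C=C/[C@H](O)C#C` gives 1 ug/mL
Compound 2 `C#C/C=C\CCCCCCCCCCCCCC/C=C/CCCC/C=C/CC/C=C/C#C[C@@H](O)C#CCCCCCC/C=C/[C@H](O)C#C` gives 1 ug/mL

In a functional assay on HCT-15 cells (Homo sapiens) for cytotoxicity (a higher number here means that more compound is needed for the effect, a lower number that less compound is needed), compound 1 at 1 ug/mL stands level with compound 2 at 1 ug/mL within the usual scatter. Compound 3 `C#C/C=C\CCCCCCCCCCCCCC/C=C/CCCC/C=C/CCCCC#C[C@@H](O)C#CCCCCCCCC[C@H](O)C#C` is still unmeasured. It differs from compound 1 by a group of 6 heavy atoms (5 carbon, 1 oxygen; no ring) in place of a group of 6 heavy atoms (5 carbon, 1 oxygen; no ring), on a saturated chain carbon, six bonds along the chain from a triple-bonded carbon on a saturated chain carbon, six bonds along the chain from a triple-bonded carbon. Among the measured compounds shown here, no measured pair shows this change, so the guidance is thin. With compound 1 at 1 ug/mL as the starting point, no step beyond the scatter is expected in this assay for this change. The expected step is no change at the digits printed from compound 1 to compound 3 (within the scatter) as an estimate. For compound 3 the estimated value is 1 ug/mL with a likely range from 0.4 ug/mL to 3 ug/mL in this measure.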

Compound 3, concentration for half-maximal effect: 3.7 ug/mL
Compound 3: the middle estimate sits 3.7-fold (0.57 log units) below what was measured; measured number above the stated range.
By their numbers in this assay, from the lowest: compounds 1 and 2 (each within the scatter of the next); then compound 3.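

In this assay, the group that enters keeps the triple bond, hydrogen-bond donor and acceptor, and heavy-atom count of the group that leaves, but lacks its double bond, and this gives a 3.7-fold higher number from compound 1 to compound 3 (0.57 log units; beyond the scatter) on the measured scale. So this place in the chain is sensitive to the change, although the step is modest. No measurement shown here explains the step. Still open, from the compounds shown here alone, is how a longer chain at this place would compare. An amine or a carboxylic acid there also remains untested among these compounds.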